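This account rests on a few compounds, and the source may have more. Where it says the series, first, only, none or still open, it means among the compounds named here.

Compound 1, `CCOC(=O)C1=C(C)N/C(=C/c2cc(C)n(-c3ccc(OC)cc3)c2C)C1=O`: in a physicochemical assay for solubility, read by nephelometry, in phosphate buffer, measured as kinetic solubility, at pH 6.5 (on this read-out lower numbers stand for lower solubility and higher numbers for higher solubility), compound 1 gives 3.1 ug/mL.
Compound 2, `CCOC(=O)C1=C(C)N/C(=C/c2cc(C)n(-c3ccc(N(C)C)cc3)c2C)C1=O`: in this assay compound 2 gives < 1.6 ug/mL, which is a limit of the assay rather than a number.

Among the measured compounds shown here, compound 2 therefore sits at the limit of < 1.6 ug/mL in this assay, at which 1 of the 2 values shown sits, and the only measured step, an at least 1.9-fold lower number from compound 1 to compound 2 (0.28 log units; that floor lies within the scatter), places it no higher than that. Compound 3, `CCOC(=O)C1=C(C)N/C(=C/c2cc(C)n(-c3ccc(CN4CCCCC4)cc3)c2C)C1=O`, differs from compound 2 by (piperidin-1-yl)methyl in place of dimethylamino on an aromatic carbon. For the measured compounds named here, no measured step involves this change, so none bears on it directly. Compound 3 is estimated to give 2.5 ug/mL in this assay, between 0.8 ug/mL and 8 ug/mL. That estimate corresponds to an expected step of an at least 1.5-fold higher number from compound 2 to compound 3 (0.19 log units; that floor lies within the scatter).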

Compound 3, solubility: 12.5 ug/mL
For compound 3 the middle estimate is 5.0-fold (0.70 log units) below the measured one; the measured number lies above the stated range.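

In this assay, among the compounds shown here, (piperidin-1-yl)methyl on this aromatic carbon gives the first change here that clearly exceeds the scatter, with a 4.0-fold higher number from compound 1 to compound 3 (0.61 log units; beyond the scatter). Set against dimethylamino, the same group gives an at least 7.8-fold higher number from compound 2 to compound 3 (0.89 log units; beyond the scatter). That step is only a floor, since the value of compound 2 is a limit of the assay and not a number: the limit of < 1.6 ug/mL in this assay, at which 1 of the 3 values shown sits.

The compounds shown leave open whether this rise follows the nitrogen or the six-membered ring of the new group. They also leave open how a morpholin-4-ylmethyl or cyclohexylmethyl group would read on the same carbon.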